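A few compounds are considered here, and "the series" means these few. Any claim that something is new, unique, unknown or untested is made for them only; others in the source may bear on it.

Measured compounds in an assay on HEK-293T cells for inhibition of diacylglycerol lipase-alpha (Homo sapiens), read by colorimetric assay; on this read-out lower numbers stand for stronger inhibition and higher numbers for weaker inhibition:
compound 1 `O=C(CCCCCCc1ccccc1)c1ncc(Cl)o1` gives > 10000 nM, which is a limit of the assay and not a number.
compound 2 `CSc1cnc(C(=O)CCCCCCc2ccccc2)o1` gives > 10000 nM, again a limit of the assay.
compound 3 `CNC(=O)c1cnc(C(=O)CCCCCCc2ccccc2)o1` gives > 10000 nM, also a limit of the assay.

Compound 3 therefore stands nowhere on a numerical scale: it sits at the limit, with the other two members of the series beside it. The three changes among the measured compounds, a step that the two limits leave unreadable from compound 1 to compound 2, a step that the two limits leave unreadable from compound 1 to compound 3 and a step that the two limits leave unreadable from compound 2 to compound 3, cannot be sized because the limit of > 10000 nM in this assay, at which 3 of the 3 values shown sit, leaves no number on either side of any of them.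

Compound 4 `O=C(CCCCCCc1ccccc1)c1ncc(-c2ccccc2F)o1` differs from compound 3 by 2-fluorophenyl in place of methylcarbamoyl on an aromatic carbon. Among the measured compounds shown here, no measured step bears on this change: every step seen so far exchanges one small group for another and none could be read. The shared core with its phenyl-bearing chain and ketone has so far given only limits, and the new group is of a different kind from any tried.

Compound 4 is accordingly estimated at 3000 nM, with a range from 300 nM to 30000 nM, the step being expected as an at least 3.3-fold lower number from compound 3 to compound 4 (0.52 log units; beyond the scatter), with the estimate held very loosely.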

Compound 4, half-maximal inhibitory concentration: > 10000 nM
Compound 4: a limit, no number (the forecaster's own chance of this, stated with the estimate: 45%); middle value at least 3.3-fold (0.52 log units) from the limit.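

Among the compounds shown here, no step to compound 4 from compound 1, compound 2 or compound 3 can be read, as all four compounds sit at the same limit: the limit of > 10000 nM in this assay, at which 4 of the 4 values shown sit.
In this assay the compounds shown leave open whether any group on this aromatic carbon of the shared core gives a number rather than a limit.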